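Replacing a dimethylaminoacetyl group with an alkylated prolyl amide

This account rests on a few compounds, and the source may have more. Where it says the series, first, only, none or still open, it means among the compounds named here.

Compound 1 `CN(C)CC(=O)N1CCC(NS(=O)(=O)c2cc(S(=O)(=O)c3ccccc3)ccc2C(F)(F)F)CC1` carries a (dimethylamino)methyl group on a carbonyl carbon whose other neighbour is an amide-type nitrogen in a ring. Within the data shown here, in an assay on isolated protein for binding affinity to secreted frizzled-related protein 1 (Homo sapiens), read by fluorescence (a lower number here means a stronger inhibitor, a higher number a weaker inhibitor), compound 1 gives 300 nM, the highest of the three numbers measured so far. Compound 2 `CCNC(=O)N1CCC[C@H]1C(=O)N1CCC(NS(=O)(=O)c2cc(S(=O)(=O)c3ccccc3)ccc2C(F)(F)F)CC1` gives 30 nM in this assay, and compound 3 `O=C([C@@H]1CCCN1C(=O)N1CCOCC1)N1CCC(NS(=O)(=O)c2cc(S(=O)(=O)c3ccccc3)ccc2C(F)(F)F)CC1` gives 40 nM. The measured steps are a 10-fold lower number from compound 1 to compound 2 (1.00 log units; beyond the scatter) and a 1.3-fold higher number from compound 2 to compound 3 (0.12 log units; within the scatter).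

Compound 4 `CC(C)(C)CCN1CCC[C@H]1C(=O)N1CCC(NS(=O)(=O)c2cc(S(=O)(=O)c3ccccc3)ccc2C(F)(F)F)CC1` differs from compound 1 as follows: 1-(3,3-dimethylbutyl)pyrrolidin-2-yl in place of (dimethylamino)methyl on a carbonyl carbon. The step from compound 1 to compound 2 bears on this change, since it also brings a pyrrolidin-2-yl group onto that carbonyl carbon and lowers the number beyond the scatter. The step from compound 2 to compound 3 shows that exchanging the group on the pyrrolidine nitrogen stayed within the scatter. Among the measured compounds shown here, no measured compound, however, carries a 3,3-dimethylbutyl group on that nitrogen in place of a carbonyl-linked group, so the expected lowering is taken as smaller and less certain. Compound 4 is expected to give 80 nM in this assay, within a range of 25 nM to 300 nM, which would mean an estimated step of a 3.8-fold lower number from compound 1 to compound 4 (0.57 log units; beyond the scatter).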

Compound 4, half-maximal inhibitory concentration: 30 nM
Compound 4: the middle estimate sits 2.7-fold (0.43 log units) above what was measured; the measured number falls inside the stated range.
By their numbers in this assay, from the lowest: compounds 2, 4 and 3 (each within the scatter of the next); then compound 1.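

In this assay the change from (dimethylamino)methyl to a pyrrolidin-2-yl group on the carbonyl carbon needs no carbonyl-linked group on the amine nitrogen in a ring: the 3,3-dimethylbutyl group gives a 10-fold lower number from compound 1 to compound 4 (1.00 log units; beyond the scatter) and matches the printed size of the step to compound 2. On that nitrogen, 3,3-dimethylbutyl in place of ethylcarbamoyl gives no change at the digits printed from compound 2 to compound 4 (within the scatter) and in place of (morpholin-4-yl)carbonyl gives a 1.3-fold lower number from compound 3 to compound 4 (0.12 log units; within the scatter) so the three groups cannot be told apart here. Nothing available explains these results.

The compounds shown leave open how much of the step belongs to the pyrrolidine ring and how much to the group on its nitrogen, which the unsubstituted secondary amine or a methyl group there would help to separate. They also leave open what a carboxylic acid at the end of the chain, or the opposite configuration at the defined stereocentre, would give.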